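Adding a Methyl to the Piperazine Ring: An Expected Step

The source may report more compounds than this note shows. Statements on the series, on what has been measured and on what is new or still open speak of the compounds shown alone.

Of the compounds shown here, two sharing one core have been tested in a functional assay on PC-3 cells (Homo sapiens) for inhibition, read by sulforhodamine B assay, with a stated time of 72 h; a lower number here means a stronger inhibitor, a higher number a weaker inhibitor. Compound 1 `Nc1sc(-c2ccc(Cl)cc2)c(-c2ccc(Cl)cc2)c1C(=O)NC1CCCCC1` carries a cyclohexylamino group on its carbonyl carbon, and compound 1 gives 7300 nM. Compound 2 `Nc1sc(-c2ccc(Cl)cc2)c(-c2ccc(Cl)cc2)c1C(=O)N1CCNCC1` carries piperazin-1-yl on that carbonyl carbon instead, and compound 2 gives 2710 nM. That change brought a 2.7-fold lower number from compound 1 to compound 2 (0.43 log units; beyond the scatter), a modest step. Compound 2 thus holds the lowest number of the two measured compounds, with compound 1 as its nearest neighbour.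

Compound 3 `CC1CN(C(=O)c2c(N)sc(-c3ccc(Cl)cc3)c2-c2ccc(Cl)cc2)CCN1` is not yet measured. It differs from compound 2 by methyl in place of hydrogen on a saturated ring carbon, turning piperazin-1-yl into 3-methylpiperazin-1-yl. Among the compounds with values here, no measured step touches a saturated ring carbon of this kind: the one step known swaps the whole group on the carbonyl carbon, so it tells little about a single added methyl on a ring that stays in place. With nothing pointing either way, a step within the scatter is expected in this assay. The expected step is a 1.1-fold lower number from compound 2 to compound 3 (0.04 log units; within the scatter). Compound 3 is therefore estimated at 2500 nM, within a range from 1000 nM to 6500 nM.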

Compound 3, half-maximal inhibitory concentration: 7210 nM
For compound 3 the middle estimate is 2.9-fold (0.46 log units) below the measured one; measured number above the stated range.
By their numbers in this assay, from the lowest: compound 2; then compounds 3 and 1 (each within the scatter of the next).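

In this assay, this saturated ring carbon turns out to matter: methyl in place of hydrogen, a change of only 1 heavy atom, gives a 2.7-fold higher number from compound 2 to compound 3 (0.42 log units; beyond the scatter) and so shows that even a small addition to the piperazin-1-yl ring can move the number beyond the scatter. The advantage that piperazin-1-yl held over cyclohexylamino does not carry over to 3-methylpiperazin-1-yl, where the comparison gives a 1.0-fold lower number from compound 1 to compound 3 (0.01 log units; within the scatter) and leaves the two compounds indistinguishable in this assay. Nothing measured alongside these compounds speaks to why the number moved.

From the compounds shown here alone, with a single substituent at this place, it remains open whether the step belongs to methyl in particular or to any group on this ring carbon, and an ethyl or a hydroxymethyl group here would help to separate the two. Going by these compounds, it also remains open whether a methyl on the ring nitrogen that bears only hydrogen in compound 2 would give a step of similar size or a different one.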